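Hydroxyethylamine in place of the prolyl amide

The source may hold more compounds than are shown below. What is called first, only, known or untested is meant among the compounds shown, and "the series" means these compounds.

Among the compounds with values here, compound 2 `O=C(NC[C@@H]1CCCc2cc(S(=O)(=O)c3cccc(F)c3)ccc21)[C@H]1CCCN1` gives 0.631 nM in an assay on isolated protein for displacement of a labelled ligand from 5-hydroxytryptamine receptor 6 (Homo sapiens) (a higher number here means a weaker inhibitor, a lower number a stronger inhibitor), the lowest of the two numbers so far; compound 1 `CNS(=O)(=O)NC[C@@H]1CCCc2cc(S(=O)(=O)c3cccc(F)c3)ccc21` gives 1 nM, and the step of a 1.6-fold lower number from compound 1 to compound 2 (0.20 log units; within the scatter) stays within the scatter. Compound 3 `O=S(=O)(c1cccc(F)c1)c1ccc2c(c1)CCC[C@H]2CNCCO` differs from compound 2 by 2-hydroxyethyl in place of (pyrrolidin-2-yl)carbonyl on an amine nitrogen. Within the data shown here, only the step from compound 1 to compound 2 touches the same amine nitrogen, and it was small, so the data give no direct guide to this larger exchange. A modest rise beyond the scatter is expected, a 4.8-fold higher number from compound 2 to compound 3 (0.68 log units; beyond the scatter). Compound 3 is estimated at 3 nM in this assay, between 0.6 nM and 15 nM.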

Compound 3, inhibition constant: 0.126 nM
Compound 3: middle estimate off by 24-fold (1.38 log units), on the high side; measured number outside the range, below it.
By their numbers in this assay, from the lowest: compound 3; then compounds 2 and 1 (each within the scatter of the next).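

On this amine nitrogen, the exchange for 2-hydroxyethyl moves the number in this assay beyond the scatter (a 5.0-fold lower number from compound 2 to compound 3 (0.70 log units; beyond the scatter); a 7.9-fold lower number from compound 1 to compound 3 (0.90 log units; beyond the scatter)), whereas the earlier exchange at the same nitrogen did not. The (pyrrolidin-2-yl)carbonyl group, with its ring and carbonyl, is therefore not required for a low number here, and the smaller, ring-free group gives the lowest number of the three. No evidence bears on the reason for this step.

The compounds shown leave open whether the hydroxyl of 2-hydroxyethyl contributes to the step. An ethyl group or a 3-hydroxypropyl chain on the same nitrogen would separate the hydroxyl from chain length.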